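A few compounds are considered here, and "the series" means these few. Any claim that something is new, unique, unknown or untested is made for them only; others in the source may bear on it.

Compound 1 `CN(C)C(=S)SC(=S)N1CCN(C(=S)SCCCC#N)CC1` — in an ADME assay on HeLa cells (Homo sapiens) for cytotoxicity, read by MTT assay, with a stated time of 24 h (a lower number here means a stronger inhibitor, a higher number a weaker inhibitor), compound 1 gives > 5000000 nM, a limit of the assay.
Compound 2 `CN(C)C(=S)SC(=S)N1CCN(C(=S)SCc2ccccc2)CC1` — in this assay compound 2 gives > 5000000 nM, likewise a limit.

Compound 2 thus stands at the limit itself. The step from compound 1 to compound 2, a step that the two limits leave unreadable from compound 1 to compound 2, cannot be read because both values sit at the limit of > 5000000 nM in this assay, at which 2 of the 2 values shown sit. Compound 3 `CCCCNC(=S)N1CCN(C(=S)SC(=S)N(C)C)CC1` differs from compound 2 by butylamino in place of benzylsulfanyl on a thiocarbonyl carbon. No measured step touches a thiocarbonyl carbon, and the single step shown is unreadable, so no step beyond the scatter can be foreseen in this assay. Compound 3 is therefore expected at 5000000 nM, within 1000000 nM to 20000000 nM. The expected step from compound 2 to compound 3 is a number no higher from compound 2 to compound 3 (the limit leaves the size open), most likely again reported only as a limit.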

Compound 3, half-maximal inhibitory concentration: 2840000 nM
For compound 3 the middle estimate is 1.8-fold (0.25 log units) above the measured one, and the stated range covers the measured number.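

In this assay compound 3 is the only one of the three to give a number rather than a limit, which makes this thiocarbonyl carbon the first place where a change yields a readable value. Butylamino in place of benzylsulfanyl gives an at least 1.7-fold lower number from compound 2 to compound 3 (0.24 log units; that floor lies within the scatter), and butylamino in place of (3-cyanopropyl)sulfanyl gives an at least 1.7-fold lower number from compound 1 to compound 3 (0.24 log units; that floor lies within the scatter). Compound 1 and compound 2 remain limits: the limit of > 5000000 nM in this assay, at which 2 of the 3 values shown sit.

On these data alone, the true size of both steps stays open, and neither can be said to exceed the scatter. As far as these compounds go, what a longer chain, a cyclic amine or a carboxylic acid would give on this thiocarbonyl carbon also stays open.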